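The source may hold more compounds than are shown below. What is called first, only, known or untested is meant among the compounds shown, and "the series" means these compounds.

Measured so far:
compound 1 `COc1cc(OC)cc(-n2c(-c3ccccc3)nc(C)c2C)c1` — 34.5%
compound 2 `COc1ccc(-n2c(-c3ccc(F)cc3)nc(C)c2C)cc1` — 39.1%

In a functional assay, read by spectrophotometry, with a stated time of 60 min, tested at 10 uM (a higher number here means a stronger effect of the compound at the concentration tested, a lower number a weaker effect), compound 2 gives 39.1%. Compound 1 gives 34.5% in this assay, and the two numbers lie within the scatter of each other, so neither stands apart. Compound 3 `COc1ccc(-n2c(-c3ccccc3)nc(C)c2C)cc1` is not yet measured and differs from compound 2 in one place: hydrogen in place of fluoro on an aromatic carbon. Going by the values given here, no measured pair shows this change, so nothing tells how large its effect is. The step of a number 3.1 percentage points lower from compound 2 to compound 3 (within the scatter) is expected to stay within the scatter, with no clear direction. Compound 3 is therefore estimated at 36%, in a range from 20% to 52%.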

Compound 3, a percentage reported as activity, at one concentration (the size of the read-out at that concentration, not a potency): 35.6%
Beside the measured number, compound 3's estimate is 0.4 percentage points above it, within the range that was stated.
By their numbers in this assay, from the lowest: compounds 1, 3 and 2 (each within the scatter of the next).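

In this assay, going by these compounds alone, the exchange of 4-fluorophenyl to phenyl gives the first measured step at this position, a number 3.5 percentage points lower from compound 2 to compound 3 (within the scatter), so fluoro and hydrogen on this aromatic carbon are not told apart here. The earlier compounds shown here offered no pair that showed this. No evidence is at hand that bears on this result. Only fluoro and hydrogen are seen on this carbon, so an amine, a carboxylic acid or a longer chain there remains an open case. On these data alone, whether any such group would give a step beyond the scatter is also open.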